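Shortening the amide chain in a bicyclic acid series

The compounds below may be only part of what the source reports. "The series", "measured", "known", "first", "only" and "open" are said of these compounds alone.

Compound 1 `CCCCNC(=O)C1C(C(=O)O)[C@@H]2CC[C@H]1O2` and compound 2 `CCc1ccccc1NC(=O)C1C(C(=O)O)[C@@H]2CC[C@H]1O2` share one core. In an ADME assay on DU-145 cells (Homo sapiens) for cytotoxicity, read by MTT assay, with a stated time of 72 h (a higher number here means a weaker inhibitor of growth, a lower number a stronger inhibitor of growth), compound 1 gives 10000 nM, and in the same assay compound 2 gives 10000 nM; the two stand level at the digits shown, within the scatter. Compound 3 `CCCNC(=O)C1C(C(=O)O)[C@@H]2CC[C@H]1O2` differs from compound 1 by hydrogen in place of methyl on a saturated chain carbon, three bonds along the chain from an amide-type nitrogen. Going by the values given here, no measured pair shows this change, and the two values at hand give no hint of movement. The step of no change at the digits printed from compound 1 to compound 3 (within the scatter) is expected to stay within the scatter. Compound 3 is expected to give 10000 nM, within a range from 5000 nM to 20000 nM.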

Compound 3, concentration for 50% growth inhibition: 10000 nM
For compound 3 middle estimate and measured number coincide at the digits printed; the measured number falls inside the stated range.
By their numbers in this assay, from the lowest: compounds 1, 2 and 3 (each within the scatter of the next).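

In this assay, going by these compounds alone, the pair gives a first reading for this position, running no change at the digits printed from compound 1 to compound 3 (within the scatter) when hydrogen replaces methyl on a saturated chain carbon, three bonds along the chain from an amide-type nitrogen. Butyl to propyl therefore leaves the read-out unmoved in this one pair, which the earlier compounds could not show. Open is whether any change at this position moves the read-out at all: an amine or a carboxylic acid on the chain, or a longer chain, remains untested among the compounds shown. Nothing at hand accounts for the flat result.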